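Aryl swap at the saturated ring carbon: chloro to furan-2-yl

A few compounds are considered here, and "the series" means these few. Any claim that something is new, unique, unknown or untested is made for them only; others in the source may bear on it.

In a functional assay on the whole organism with Mus musculus as the target, in the maximal electroshock model, with a stated time of 4 h (a higher number here means that more compound is needed for the effect, a lower number that less compound is needed), compound 1 `SC1=NC(n2nc(-c3ccccc3)nc2-c2ccccc2)=CC(c2ccc(Cl)cc2)N1` gives 300 mg/kg. Compound 2 `O=[N+]([O-])c1cccc(C2C=C(n3cc(-c4ccccc4)nc3-c3ccccc3)N=C(S)N2)c1` gives 300 mg/kg and compound 3 `CN(C)c1ccc(C2C=C(n3cc(-c4ccccc4)nc3-c3ccccc3)N=C(S)N2)cc1` gives 300 mg/kg in this assay; compound 1 stands level with both at the digits shown, within the scatter. Among the compounds with values here, the one measured step, no change at the digits printed from compound 2 to compound 3 (within the scatter), is the sole comparison on hand for a change of the aryl group at this position. Compound 4 `SC1=NC(n2nc(-c3ccccc3)nc2-c2ccccc2)=CC(c2ccc(-c3ccco3)cc2)N1` differs from compound 1 as follows: furan-2-yl in place of chloro on an aromatic carbon. Given that the only comparable step showed no movement, the expected step of no change at the digits printed from compound 1 to compound 4 (within the scatter) from compound 1 to compound 4 is none beyond the scatter. Compound 4 is therefore estimated at 300 mg/kg in this assay, with a range from 150 mg/kg to 600 mg/kg.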

Compound 4, minimum effective dose: 300 mg/kg
The estimate for compound 4 equals the measured number at the digits printed, within the range that was stated.
By their numbers in this assay, from the lowest: compounds 1, 2, 3 and 4 (each within the scatter of the next).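

In this assay, furan-2-yl in place of chloro gives no change at the digits printed from compound 1 to compound 4 (within the scatter). Within the data shown here, this is the first step read on the core of compound 1, and it shows that a five-membered aromatic ring with one hydrogen-bond acceptor can replace a single chlorine on this aromatic carbon without a measurable difference. No measured data on hand account for this flat reading. On these data alone, whether an amine, a carboxylic acid or a longer chain at this place would separate from the four compounds remains open. So does whether any change elsewhere on the core would do so.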